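The source may hold more compounds than are shown below. What is called first, only, known or untested is meant among the compounds shown, and "the series" means these compounds.

Of the compounds shown here, three share one core and have been measured in a functional assay on MCF7 cells (Homo sapiens) for antiproliferative activity, read by sulforhodamine B assay, with a stated time of 72 h; a higher number here means a weaker inhibitor, a lower number a stronger inhibitor. Compound 1 `FC(F)(F)c1ccc(CN2CCN(Cc3cc(-c4ccc(OCc5ccccc5)cc4)on3)CC2)cc1` gives 2900 nM. Compound 2 `N#Cc1ccccc1COc1ccc(-c2cc(CN3CCN(Cc4ccc(C(F)(F)F)cc4)CC3)no2)cc1` adds a cyano group to the outer ring of the benzyloxy arm, and in this assay compound 2 gives 4000 nM; the step of a 1.4-fold higher number from compound 1 to compound 2 (0.14 log units; within the scatter). Compound 3 `Fc1cccc(COc2ccc(-c3cc(CN4CCN(Cc5ccc(C(F)(F)F)cc5)CC4)no3)cc2)c1` instead adds a fluoro group there, and compound 3 gives 2500 nM; the step of a 1.2-fold lower number from compound 1 to compound 3 (0.06 log units; within the scatter), and the step of a 1.6-fold lower number from compound 2 to compound 3 (0.20 log units; within the scatter). Compound 3 thus holds the lowest number of the three, yet each gap to the other two lies within the scatter, so the three compounds cannot be told apart with confidence on these numbers.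

Compound 4 `COc1cccc(COc2ccc(-c3cc(CN4CCN(Cc5ccc(C(F)(F)F)cc5)CC4)no3)cc2)c1` differs from compound 3 by a single change: methoxy in place of fluoro on an aromatic carbon. All three measured steps alter this same outer ring, and every one of them stayed within the scatter, so substitution on that ring has so far moved the read-out little. The change is therefore expected to produce a 1.1-fold higher number from compound 3 to compound 4 (0.05 log units; within the scatter), with no shift beyond the scatter in either direction. Compound 4 is estimated at 2800 nM in this assay, with a range from 1400 nM to 5600 nM.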

Compound 4, half-maximal inhibitory concentration: 2000 nM
Estimate against measurement, compound 4: 1.4-fold (0.15 log units) above; the measured number falls inside the stated range.
By their numbers in this assay, from the lowest: compounds 4, 3, 1 and 2 (each within the scatter of the next).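

Replacing fluoro with methoxy on the outer ring puts two heavy atoms where there was one, and adds one hydrogen-bond acceptor by the count for these groups, yet the read-out in this assay shows only a 1.3-fold lower number from compound 3 to compound 4 (0.10 log units; within the scatter). The comparisons with the other two compounds agree, with a 1.5-fold lower number from compound 1 to compound 4 (0.16 log units; within the scatter) and a 2.0-fold lower number from compound 2 to compound 4 (0.30 log units; within the scatter); this last step is the largest among the four compounds, but it still does not pass the scatter, so this larger oxygen-bearing group gives no measurable separation from hydrogen, fluoro or cyano on this ring. Nothing available explains why the number stays so flat across these changes.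

On these data alone, whether an amine or a carboxylic acid on this ring would move the number beyond the scatter remains open, as does the effect of replacing the trifluoromethyl group at the far end of the molecule, which stays the same in all four compounds. Methoxy also appears here at only one place on the ring, so its effect elsewhere on that ring is unknown.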